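From 4-chlorophenyl to 2-methylphenyl on the shared core

This account rests on a few compounds, and the source may have more. Where it says the series, first, only, none or still open, it means among the compounds named here.

Measured so far in an ADME assay on HUVEC cells (Homo sapiens) for cytotoxicity, read by MTT assay, with a stated time of 24 h (a lower number here means that less compound is tolerated, a higher number that more compound is tolerated), for two compounds:
- compound 1 `Clc1ccccc1/C=C/c1nnc(-c2ccc3c(c2)OCCO3)o1` gives 368000 nM
- compound 2 `Clc1ccc(/C=C/c2nnc(-c3ccc4c(c3)OCCO4)o2)cc1` gives 312000 nM

Going by the values given here, on these numbers compound 2 stands level with compound 1, the only other compound measured. The next compound, compound 3 `Cc1ccccc1/C=C/c1nnc(-c2ccc3c(c2)OCCO3)o1` differs from compound 2 as follows: 2-methylphenyl in place of 4-chlorophenyl on a double-bonded chain carbon bound to a double-bonded chain carbon with 2-methylphenyl in place of 4-chlorophenyl on a double-bonded chain carbon bound to a double-bonded chain carbon. One measured change at that place bears on this: a 1.2-fold lower number from compound 1 to compound 2 (0.07 log units; within the scatter) with 4-chlorophenyl in place of 2-chlorophenyl. Among the compounds with values here, no measured compound yet carries 2-methylphenyl, so the evidence is thin. Given the small size of that one step, no change beyond the scatter is expected in this assay and no direction is favoured. The estimate means a 1.1-fold higher number from compound 2 to compound 3 (0.02 log units; within the scatter) as the expected step. For compound 3 the expected value is 330000 nM with an estimated range from 150000 nM to 650000 nM as its bounds.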

Compound 3, half-maximal cytotoxic concentration: 356000 nM
Compound 3: middle estimate off by 1.1-fold (0.03 log units), on the low side; measured number inside the range.
By their numbers in this assay, from the lowest: compounds 2, 3 and 1 (each within the scatter of the next).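

In this assay, the step of a 1.1-fold higher number from compound 2 to compound 3 (0.06 log units; within the scatter) stays within the scatter, so 2-methylphenyl joins 2-chlorophenyl and 4-chlorophenyl as a third group on a double-bonded chain carbon bound to a double-bonded chain carbon with no measurable difference among them. The new comparison of methyl in place of chloro on an aromatic carbon, a 1.0-fold lower number from compound 1 to compound 3 (0.01 log units; within the scatter), is also within the scatter, so this change at this place leaves the number where it was. Nothing available gives a reason for this flat result.

The compounds shown leave open whether a group of a different kind at this place, such as an amine, a carboxylic acid or a longer chain, would move the number beyond the scatter. They also leave open whether 4-methylphenyl would behave as 2-methylphenyl does.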